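Trimming the sugar-bearing side chain of compound 2

This account rests on a few compounds, and the source may have more. Where it says the series, first, only, none or still open, it means among the compounds named here.

Three close relatives of one purine-like core have been measured in a functional assay on the whole organism (B cells) with Mus musculus as the target; on this read-out lower numbers stand for smaller maximal responses and higher numbers for larger maximal responses. Compound 1 `CCCn1c(=O)n(C2CCC(COC(C)=O)O2)c2nc(NC(C)=O)nc(O)c21` gives 100%, compound 3 `C=CCn1c(=O)n(C2C[C@H](O)C(CO)O2)c2nc(N)nc(O)c21` gives 99%, and compound 2 `Nc1nc(O)c2c(n1)n(C1OC(CO)[C@@H](O)[C@H]1O)c(=O)n2CC(O)CO` gives 136%. Among these three numbers compound 2 stands highest: its value lies beyond the usual scatter above compound 1, the nearest of the two, and likewise beyond the scatter above compound 3, the furthest.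

Compound 4 `Cn1c(=O)n(C2OC(CO)[C@@H](O)[C@H]2O)c2nc(N)nc(O)c21` has not yet been tested in this assay. It differs from compound 2 in one place: hydrogen in place of 1,2-dihydroxyethyl on a saturated chain carbon bound to an aromatic nitrogen. Among the measured compounds shown here, no step between two measured compounds covers this change, so its effect must be guessed from the surrounding numbers. The two measured compounds without this chain, compound 1 and compound 3, both sit well below compound 2 in this assay, which suggests a downward step of a size beyond the scatter.

The step from compound 2 to compound 4 in this assay is therefore expected to be a number 31 percentage points lower from compound 2 to compound 4 (beyond the scatter). For compound 4 the estimated value is 105%, with a range from 80% to 135%.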

Compound 4, largest response reached (reported as maximal response), in percent of the reference or control that the assay uses: 99%
For compound 4 the middle estimate is 6 percentage points above the measured one; the range from low to high includes it.
By their numbers in this assay, from the lowest: compounds 3, 4 and 1 (each within the scatter of the next); then compound 2.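

In this assay, among the compounds shown here, replacing 1,2-dihydroxyethyl with hydrogen on a saturated chain carbon bound to an aromatic nitrogen gives a number 37 percentage points lower from compound 2 to compound 4 (beyond the scatter) as the first direct reading of a single change at this place. Cut one bond further out, the same difference reads 2,3-dihydroxypropyl to methyl, so the larger maximal response in this pair goes with the dihydroxypropyl chain, while the rest of the structure stays the same. Nothing measured here explains why this change lowers the response.

The pair cannot separate the part played by the two hydroxyl groups from that of the chain length, and compounds 1 and 3 differ from compound 2 in more than one place, so they cannot settle this. On these data alone, it also remains open how a 2-hydroxyethyl chain, an aminoethyl chain or a carboxylic acid on the chain would behave here.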